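The source may report more compounds than this note shows. Statements on the series, on what has been measured and on what is new or still open speak of the compounds shown alone.

Measured so far in a functional assay on HCC827 cells (Homo sapiens) for antiproliferative activity, read by MTT assay, with a stated time of 72 h; a higher number here means a weaker inhibitor, a lower number a stronger inhibitor:
- compound 1, `CN1CCN(c2ccc(Nc3ncc4nc(Nc5ccc(F)cc5)n(CCNS(=O)(=O)C5CC5)c4n3)cc2)CC1`: 50 nM
- compound 2, `CN1CCN(c2ccc(Nc3ncc4nc(Nc5ccccc5)n([C@H]5CCNC5)c4n3)cc2)CC1`: 530 nM
- compound 3, `CN1CCN(c2ccc(Nc3ncc4nc(Nc5ccccc5)n([C@@H]5CCN(C(=O)OC(C)(C)C)C5)c4n3)cc2)CC1`: 12 nM

Compound 1 stands second highest of the three numbers, its nearest neighbour being compound 3, with a lower number beyond the scatter, and its furthest compound 2, with a higher number beyond the scatter.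

Compound 4, `CC(=O)Nc1cccc(-n2c(Nc3ccc(F)cc3)nc3cnc(Nc4ccc(N5CCN(C)CC5)cc4)nc32)c1`, differs from compound 1 at the aromatic nitrogen of the shared core:

3-acetamidophenyl in place of 2-((cyclopropylsulfonyl)amino)ethyl on an aromatic nitrogen

Among the measured compounds shown here, only one measured step touches this position: a 44-fold lower number from compound 2 to compound 3 (1.65 log units; beyond the scatter). It shows that the group on this aromatic nitrogen can move the number a long way, but it exchanges one pyrrolidin-3-yl for a 1-(tert-butoxycarbonyl)pyrrolidin-3-yl, not a 2-((cyclopropylsulfonyl)amino)ethyl for a 3-acetamidophenyl, so it sets no direction for the present change. The three measured groups at this nitrogen span a wide range, and compound 1 sits inside it.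

For the measured compounds named here, with no direct precedent, compound 4 is expected to land near compound 1, with a slight lean toward the lower end because compound 3 gives 12 nM and also carries a larger group at this nitrogen; the estimated step is a 1.7-fold lower number from compound 1 to compound 4 (0.22 log units; within the scatter). Compound 4 is therefore estimated at 30 nM, within a range of 6 nM to 150 nM.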

Compound 4, half-maximal inhibitory concentration: 10 nM
Compound 4: middle estimate off by 3.0-fold (0.48 log units), on the high side; low and high end bracket the measured number.
By their numbers in this assay, from the lowest: compounds 4 and 3 (each within the scatter of the next); then compound 1; then compound 2.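

Among the compounds shown here, the step of a 5.0-fold lower number from compound 1 to compound 4 (0.70 log units; beyond the scatter) is the first reading at this aromatic nitrogen in this assay with the (4-fluorophenyl)amino group held constant, and the first to exchange an open chain for a six-membered aromatic ring of carbon only; the earlier step, a 44-fold lower number from compound 2 to compound 3 (1.65 log units; beyond the scatter), stayed within the pyrrolidin-3-yl pair. Here, the 3-acetamidophenyl group gives a lower number than the 2-((cyclopropylsulfonyl)amino)ethyl group, so neither the cyclopropylsulfonyl unit nor the three-membered ring is needed for a low number in this pair, and the substituent on this nitrogen can be attached directly through an aromatic ring. No measurement is available that accounts for the size or direction of this step.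

This single pair does not separate the contribution of the aromatic ring from that of the acetamide, and an unsubstituted phenyl group or a 3-aminophenyl group on the same nitrogen would divide the two. Also open, on these data alone, is whether the gain carries over to a longer chain ending in the same acetamide, which would keep the amide while removing the ring.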